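Removing the 4-Methylpiperazin-1-yl Group from Two Cores

The compounds below may be only part of what the source reports. "The series", "measured", "known", "first", "only" and "open" are said of these compounds alone.

Compound 1 `CN1CCN(c2ccc(NC(=N)c3cc4cn(C)nc4cn3)cc2)CC1` carries a 4-methylpiperazin-1-yl group on a six-membered aromatic ring of carbon only. In a functional assay on MDA-MB-231 cells (Homo sapiens) for cytotoxicity, read by MTT assay, with a stated time of 72 h (a higher number here means a weaker inhibitor, a lower number a stronger inhibitor), compound 1 gives 20500 nM. Compound 2 `COc1ccc(Cn2nc(-c3ccccc3)c3cc(C(=N)Nc4ccc(N5CCN(C)CC5)cc4)nc(Nc4cc(OC)c(OC)c(OC)c4)c32)cc1` carries the same group on the same kind of ring, but on a much larger core; how the two cores differ is not broken down here. In this assay compound 2 gives 890 nM, a lower number than compound 1 shows. Compound 3 `COc1ccc(Cn2nc(-c3ccccc3)c3cc(C(=N)Nc4ccccc4)nc(Nc4cc(OC)c(OC)c(OC)c4)c32)cc1` is compound 2 with one change, (hydrogen in place of 4-methylpiperazin-1-yl on an aromatic carbon). In this assay compound 3 gives 42100 nM, so that a 47-fold higher number from compound 2 to compound 3 (1.67 log units; beyond the scatter).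

Compound 4 `Cn1cc2cc(C(=N)Nc3ccccc3)ncc2n1` is the unmeasured member of the set. It is compound 1 with hydrogen in place of 4-methylpiperazin-1-yl on an aromatic carbon. The place described for this change reads the same for both pairs, so it is the same change, and it occurs twice among these compounds, once measured and once not.

For compound 4 in this assay the expected step is a 7.3-fold higher number from compound 1 to compound 4 (0.86 log units; beyond the scatter), set beside the measured one. This expectation rests on compound 3, whose value 42100 nM reflects the removal of the same group from compound 2. Compound 1 already gives 20500 nM, so the result for compound 4 is expected to be a higher number still. Compound 4 is estimated at 150000 nM, expected to lie between 30000 nM and 800000 nM.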

Compound 4, half-maximal inhibitory concentration: > 50000 nM
Compound 4 was reported as a limit; the forecaster's own chance of this, stated with the estimate: 50%; the middle value is on the limit's open side.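

In this assay the result for compound 4 is a limit and not a number: the limit of > 50000 nM in this assay, at which 1 of the 4 values shown sits.

Even so, the change can be read in one direction on both cores, since hydrogen in place of 4-methylpiperazin-1-yl gives an at least 2.4-fold higher number from compound 1 to compound 4 (0.38 log units; beyond the scatter), and on the larger core the same change gives a 47-fold higher number from compound 2 to compound 3 (1.67 log units; beyond the scatter). This shows that, in the two pairs available, the change moves the number the same way on both cores, but it does not show that the size of the step carries over from one core to the other: the same change on two cores in this assay, a 47-fold higher number (1.67 log units; beyond the scatter) from compound 2 to compound 3 and an at least 2.4-fold higher number (0.38 log units; beyond the scatter) from compound 1 to compound 4; the limit leaves it open whether they differ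

The compounds shown have only 4-methylpiperazin-1-yl or hydrogen at this place on the six-membered aromatic ring of carbon only, so it remains open how a morpholine, a primary amine or a carboxylic acid there would read in this assay on either core. For the compounds shown here, with only two cores in view, it is also open whether the direction seen in these two pairs would hold on any further core.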